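Iodo and cyano removal on a shared diaryl ether core

The source may hold more compounds than are shown below. What is called first, only, known or untested is meant among the compounds shown, and "the series" means these compounds.

In an ADME assay on MT4 cells (Homo sapiens) for cytotoxicity, read by MTT assay, with a stated time of 5 days (on this read-out lower numbers stand for higher toxicity in this test and higher numbers for lower toxicity in this test), compound 1 `Cc1cc(C#N)cc(C)c1Oc1cc(Nc2ccc(C#N)cc2)[nH]c(=O)c1I` gives > 259000 nM, which is a limit of the assay rather than a number, namely (the limit of > 259000 nM in this assay, at which 1 of the 3 values shown sits). Compound 2 `Cc1cc(C#N)cc(C)c1Oc1cc(Nc2ccc(C#N)cc2)[nH]c(=O)c1` gives 25000 nM in this assay. Compound 3 `Cc1cccc(C)c1Oc1cc(Nc2ccc(C#N)cc2)[nH]c(=O)c1I` gives 28000 nM in this assay, and compound 2 and compound 3 lie within the usual scatter of each other. Compound 1 and compound 2 differ by hydrogen in place of iodo on an aromatic carbon, giving an at least 10-fold lower number from compound 1 to compound 2 (1.01 log units; beyond the scatter). The cores of compound 3 and compound 1 differ by hydrogen in place of cyano on an aromatic carbon, giving an at least 9.2-fold lower number from compound 1 to compound 3 (0.96 log units; beyond the scatter). Compound 4 `Cc1cccc(C)c1Oc1cc(Nc2ccc(C#N)cc2)[nH]c(=O)c1` is not yet measured in this assay; it differs from compound 3 by hydrogen in place of iodo on an aromatic carbon, the same kind of change as from compound 1 to compound 2, though around the place compound 3 reads ortho to a group of 9 heavy atoms and para to a group of 9 heavy atoms, where compound 1 reads ortho to a large group and para to a (4-cyanophenyl)amino group (9 heavy atoms). The step is expected to be a 1.9-fold lower number from compound 3 to compound 4 (0.27 log units; within the scatter), smaller than the earlier one. This rests on compound 3 already giving 28000 nM, within the scatter of compound 2 at 25000 nM. The earlier step, by contrast, set out from compound 1, whose value is a limit of the assay. For compound 4 the estimate in this assay is 15000 nM, expected between 4000 nM and 60000 nM.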

Compound 4, half-maximal cytotoxic concentration: 36000 nM
Estimate against measurement, compound 4: 2.4-fold (0.38 log units) below; the measured number falls inside the stated range.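

In this assay, hydrogen in place of iodo gives a 1.3-fold higher number from compound 3 to compound 4 (0.11 log units; within the scatter), and this step does not match the same change on the core of compound 1: the same change on two cores in this assay, an at least 10-fold lower number (1.01 log units; beyond the scatter) from compound 1 to compound 2 and a 1.3-fold higher number (0.11 log units; within the scatter) from compound 3 to compound 4, at least 13-fold (1.12 log units) apart, beyond the scatter of two such steps

Hydrogen in place of cyano gives a 1.4-fold higher number from compound 2 to compound 4 (0.16 log units; within the scatter), and this step also differs from its counterpart on the core of compound 1: the same change on two cores in this assay, an at least 9.2-fold lower number (0.96 log units; beyond the scatter) from compound 1 to compound 3 and a 1.4-fold higher number (0.16 log units; within the scatter) from compound 2 to compound 4, at least 13-fold (1.12 log units) apart, beyond the scatter of two such steps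

Compound 1, the only compound shown that carries both iodo and cyano, gives > 259000 nM, a limit of the assay and not a number, so the size of its steps stays unfixed, and the series shows that neither change carries over between these cores but not why.

As far as these compounds go, it remains open whether the reading of compound 1 depends on iodo itself or would persist with a bromo, chloro or methyl group there. Also open, from the compounds shown here alone, is whether a carboxylic acid or an amide in place of the nitrile would give a step like either of those from compound 1.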